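The source may report more compounds than this note shows. Statements on the series, on what has been measured and on what is new or still open speak of the compounds shown alone.

Measured in a functional assay on CNE2Z cells (Homo sapiens) for inhibition, read by MTT assay, with a stated time of 72 h; a higher number here means a weaker inhibitor, a lower number a stronger inhibitor:
- Compound 1 `C=CCc1ccc(OCc2ccc(Cl)cc2Cl)c(-c2ccc(OCc3ccc(Cl)cc3Cl)c(CC=C)c2)c1`: > 50000 nM, a limit of the assay and not a number
- Compound 2 `C=CCc1ccc(OCc2ccc(Cl)cc2Cl)c(-c2ccc(O)c(CC=C)c2)c1`: 24200 nM
- Compound 3 `C=CCc1ccc(O)c(-c2ccc(OCc3c(Cl)cccc3Cl)c(CC=C)c2)c1`: 16400 nM

Compound 2 gives 24200 nM and compound 3 gives 16400 nM. These two numbers lie within the usual scatter of each other, so they cannot be ranked.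

Compound 4 `C=CCc1ccc(OCc2ccc(Cl)c(Cl)c2)c(-c2ccc(O)c(CC=C)c2)c1` has not yet been measured. It differs from compound 2 as follows: 3,4-dichlorophenyl in place of 2,4-dichlorophenyl on a saturated chain carbon bound to an oxygen on an aromatic ring. Here 3,4-dichlorophenyl stands in place of 2,4-dichlorophenyl on a saturated chain carbon bound to an oxygen on an aromatic ring, with the same atoms joined differently.

Within the data shown here, the only measured step touching this group is an at least 2.0-fold lower number from compound 1 to compound 2 (0.31 log units; beyond the scatter). That step put hydrogen in place of a whole 2,4-dichlorobenzyl, and its size is open-ended, resting on (the limit of > 50000 nM in this assay, at which 1 of the 3 values shown sits). Among the measured compounds shown here, no measured step shows what a rearrangement within the group does, so compound 4 is expected to stay close to compound 2, which gives 24200 nM in this assay.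

The expected step is a 1.2-fold lower number from compound 2 to compound 4 (0.08 log units; within the scatter), which stays within the scatter. For compound 4 the estimated value is 20000 nM, with an expected range from 9000 nM to 45000 nM.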

Compound 4, half-maximal inhibitory concentration: 14200 nM
Beside the measured number, compound 4's estimate is 1.4-fold (0.15 log units) above it; measured number inside the range.
By their numbers in this assay, from the lowest: compounds 4, 3 and 2 (each within the scatter of the next). At a limit, above all of these: compound 1.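

The earlier step replaced the whole 2,4-dichlorobenzyl with hydrogen, whereas this one only rearranges the same atoms, turning it into 3,4-dichlorobenzyl. In this assay, that rearrangement gives a 1.7-fold lower number from compound 2 to compound 4 (0.23 log units; within the scatter), so this pair shows no readable effect of the change from 2,4-dichlorophenyl to 3,4-dichlorophenyl on this saturated chain carbon. Compound 1 remains a limit of the assay and not a number, so the size of the only step that removes this group is still open-ended: the limit of > 50000 nM in this assay, at which 1 of the 4 values shown sits.

As far as these compounds go, it remains open whether a benzyl with no chlorine at all, or one carrying a single chlorine, would give a number beyond the scatter of compound 2. The same question stands for a benzyl carrying a methoxy group, an amine or a carboxylic acid in place of the chlorines.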